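Swapping Bromo for Chloro on a Weak Inhibitor

The compounds below may be only part of what the source reports. "The series", "measured", "known", "first", "only" and "open" are said of these compounds alone.

Measured compounds:
Compound 1, `COc1ccc(C2=C(Br)C(=O)c3ccc(C)cc32)cc1`: 43200 nM
Compound 2, `COc1ccc(C2=C(Br)C(=O)c3ccc(C)cc32)cc1OC`: > 50000 nM, a limit of the assay
Compound 3, `Cc1ccc(C2=C(Br)C(=O)c3ccc(C)cc32)cc1`: > 50000 nM, a limit of the assay

All three share one core and were tested in an assay on isolated protein for inhibition of alpha-ketoglutarate-dependent dioxygenase alkB homolog 3 (Homo sapiens), read by fluorescence, with stated times of 60 min and 15 min; a higher number here means a weaker inhibitor, a lower number a stronger inhibitor. Among the measured compounds shown here, compound 1 gives 43200 nM, the only true number in the set. For compound 2 the assay reports > 50000 nM, which is a limit rather than a number. For compound 3 the assay likewise reports > 50000 nM, again a limit. The steps of an at least 1.1-fold higher number from compound 1 to compound 2 (0.06 log units; that floor lies within the scatter) and an at least 1.1-fold higher number from compound 1 to compound 3 (0.06 log units; that floor lies within the scatter) thus have floors within the scatter, both ending at the limit of > 50000 nM in this assay, at which 2 of the 3 values shown sit.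

Compound 4, `COc1ccc(C2=C(Cl)C(=O)c3ccc(C)cc32)cc1`, is not yet measured. It differs from compound 1 by chloro in place of bromo on a double-bonded ring carbon. Neither measured step bears on this change: both alter a group on an aromatic carbon, not the halogen on the five-membered ring. For the measured compounds named here, with no step to anchor a shift in this assay, the expected change is none beyond the scatter, leaning toward a somewhat higher number in view of the limit of > 50000 nM in this assay, at which 2 of the 3 values shown sit.

Compound 4 is therefore estimated at about 48000 nM, within a range from 20000 nM to 110000 nM. That estimate means an expected step of a 1.1-fold higher number from compound 1 to compound 4 (0.05 log units; within the scatter), which stays within the scatter.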

Compound 4, half-maximal inhibitory concentration: > 50000 nM
Compound 4 ended at the assay's limit; the forecaster's own chance of this, stated with the estimate: 45%; middle value at least 1.0-fold (0.01 log units) away from the limit.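

Among the compounds shown, only compound 4 changes the halogen itself, on a double-bonded ring carbon of the five-membered ring, while compound 2 and compound 3 keep bromo there and alter a group on an aromatic carbon. In this assay, chloro in place of bromo gives an at least 1.1-fold higher number from compound 1 to compound 4 (0.06 log units; that floor lies within the scatter), so this change brings no lower number, and bromo cannot be replaced by chloro here with any visible gain. The result for compound 4 is a limit and not a number, so the true size of the step cannot be read, and the compounds now crowd one end of the scale: the limit of > 50000 nM in this assay, at which 3 of the 4 values shown sit.

The compounds shown leave open whether a different group on this ring carbon, such as fluoro, iodo, an amine or a nitrile, would bring the number down from that of compound 1. They also leave open whether an amine or a carboxylic acid on the aromatic ring, in place of the methoxy of compound 1, would give a number that can be read at all.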